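Swapping trifluoromethyl for fluoro on a tolerated pyrazole amide

The source may report more compounds than this note shows. Statements on the series, on what has been measured and on what is new or still open speak of the compounds shown alone.

Measured compounds:
- compound 1, `CCOC(=O)c1cn(-c2ccccc2[N+](=O)[O-])nc1CC(C)C`, 4850 nM
- compound 2, `CC(C)Cc1nn(-c2nccs2)cc1C(=O)NCc1ccc(C(F)(F)F)cc1`, > 100000 nM

Both compounds were tested in a toxicity assay on HepG2 2.2.15 cells (Homo sapiens) for cytotoxicity, read by CCK-8 assay, with a stated time of 8 days; a higher number here means that more compound is tolerated, a lower number that less compound is tolerated. Compound 1 gives a measured number there, 4850 nM. For compound 2 the outcome is different in kind: compound 2 reaches > 100000 nM, which is a limit of the assay and not a number, so it only tells that compound 2 is tolerated up to the highest concentration tested, as noted in the limit of > 100000 nM in this assay, at which 1 of the 2 values shown sits. For the measured compounds named here, compound 2 and compound 1 share no single-point difference, so their two values show only that compound 2 is the more tolerated of the pair.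

Compound 3, `CC(C)Cc1nn(-c2nccs2)cc1C(=O)NCc1ccc(F)cc1`, has not yet been measured in this assay. It differs from compound 2 in one place: fluoro in place of trifluoromethyl on an aromatic carbon. With no measured step of this kind in hand, the expected step from compound 2 to compound 3 in this assay is a number no higher from compound 2 to compound 3 (the limit leaves the size open), no more than the usual scatter. Compound 3 is therefore estimated at 100000 nM, with a range from 30000 nM to 300000 nM, and most likely it will again return only a limit.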

Compound 3, half-maximal cytotoxic concentration: > 100000 nM
Compound 3 gave a limit, no number; the forecaster's own chance of this, stated with the estimate: 75%; the middle value lies on the limit itself.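

In this assay compound 3 gives > 100000 nM, which is a limit of the assay and not a number. For the compounds shown here, compound 2 also stands at a limit, so no step between compound 2 and compound 3 can be read: the limit of > 100000 nM in this assay, at which 2 of the 3 values shown sit. The compounds shown leave open whether fluoro in place of trifluoromethyl changes tolerance in this assay at all.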